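A Carboxy Group Replaces Chloro

The source may report more compounds than this note shows. Statements on the series, on what has been measured and on what is new or still open speak of the compounds shown alone.

compound 1 `O=C(O)c1cc(NC(=O)c2ccc(Cl)cc2)cc(C(=O)O)c1` - 97.3 mg/kg
compound 2 `O=C(Nc1ccc(-c2nn[nH]n2)cc1)c1cccc(-c2nn[nH]n2)c1` - 0.6 mg/kg

In a functional assay on the whole organism (stomach) with Rattus norvegicus as the target (a lower number here means that less compound is needed, a higher number that more compound is needed for the effect), compound 1 has the higher of the two numbers, and compound 2 lies far below it, well beyond the usual scatter. Compound 3 `O=C(O)c1ccc(C(=O)Nc2cc(C(=O)O)cc(C(=O)O)c2)cc1` departs from compound 1 in one place, on an aromatic carbon para to a large group, where carboxy stands in place of chloro (carboxy in place of chloro on an aromatic carbon). Within the data shown here, no pair of measured compounds shows what this change does, so the data offer no direct guide to its size. The low number of compound 2 at 0.6 mg/kg shows only that much lower doses are reachable in this assay. A moderate move towards a lower number is therefore expected, estimated as a 2.8-fold lower number from compound 1 to compound 3 (0.44 log units; beyond the scatter). Compound 3 is expected at 35 mg/kg, with an estimated range from 6 mg/kg to 150 mg/kg.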

Compound 3, dose for 50% inhibition: 32.2 mg/kg
The estimate for compound 3 lay 1.1-fold (0.04 log units) above the measured number; measured number inside the range.
By their numbers in this assay, from the lowest: compound 2; then compound 3; then compound 1.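

In this assay, the aromatic carbon para to a large group now has a measured change: carboxy in place of chloro gives a 3.0-fold lower number from compound 1 to compound 3 (0.48 log units; beyond the scatter), a modest step that still lies beyond the usual scatter. This shows that the number responds to a change at this position and that chloro is not required there for the effect, as compound 3 keeps it measurable without that group. No measurement shown here accounts for the step.

From the compounds shown here alone, whether a methyl ester or an amine at this position would move the number further in the same direction remains open. Compound 2 differs from compound 1 and compound 3 in more than one place, so the compounds shown do not tell which of its features goes with its lower number.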